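Swapping the aminophenyl for a furan

A few compounds are considered here, and "the series" means these few. Any claim that something is new, unique, unknown or untested is made for them only; others in the source may bear on it.

Measured so far in a functional assay on U-251 cells (Homo sapiens) for antiproliferative activity, read by MTT assay, with a stated time of 48 h; on this read-out higher numbers stand for weaker inhibition and lower numbers for stronger inhibition
- Compound 1 `COc1cccc(-c2nc3cccc(-c4cc(OC)c(OC)c(OC)c4)c3o2)c1` gives > 25000 nM (a limit, not a number)
- Compound 2 `COc1cc(-c2cccc3nc(-c4cccc(N)c4)oc23)cc(OC)c1OC` gives 2200 nM

Within the data shown here, compound 2 holds the only true number so far, as the other reading is a limit. Compound 3 `COc1cc(-c2cccc3nc(-c4ccco4)oc23)cc(OC)c1OC` differs from compound 2 in one place: furan-2-yl in place of 3-aminophenyl on an aromatic carbon. In words, this is furan-2-yl in place of 3-aminophenyl on an aromatic carbon. Among the measured compounds shown here, one measured step bears on the change, and it is large and beyond the scatter: an at least 11-fold lower number from compound 1 to compound 2 (1.05 log units; beyond the scatter), with amino in place of methoxy on an aromatic carbon. For the measured compounds named here, compound 3 has no amino group, so part of that step in this assay is expected to be lost, although no furan-2-yl compound has yet been measured. The estimated change is a 4.5-fold higher number from compound 2 to compound 3 (0.66 log units; beyond the scatter), towards weaker inhibition. For compound 3 the estimate is 10000 nM, with an expected range of 3000 nM to 25000 nM.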

Compound 3, half-maximal inhibitory concentration: 10600 nM
The estimate for compound 3 lay 1.1-fold (0.03 log units) below the measured number; low and high end bracket the measured number.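

In this assay, the place on the five-membered aromatic ring with 1 nitrogen and 1 oxygen now shows a second kind of change: furan-2-yl in place of 3-aminophenyl gives a 4.8-fold higher number from compound 2 to compound 3 (0.68 log units; beyond the scatter), so compound 2 keeps a clear lead over a ring with no amino group. Furan-2-yl in place of 3-methoxyphenyl gives an at least 2.3-fold lower number from compound 1 to compound 3 (0.37 log units; beyond the scatter), which shows that a gain at this place does not need an amino group. This second step rests on a limit, not a number, for compound 1: the limit of > 25000 nM in this assay, at which 1 of the 3 values shown sits.

The compounds shown do not tell whether the lead of compound 2 comes from the amino group alone or also from the phenyl ring that carries it. An unsubstituted phenyl, a 3-hydroxyphenyl or a thiophen-2-yl at this place remains an open case.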